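From compound 1 to compound 4: one group exchanged

The compounds below may be only part of what the source reports. "The series", "measured", "known", "first", "only" and "open" are said of these compounds alone.

Measured in a functional assay on HepG2 cells (Homo sapiens) for inhibition, read by MTT assay, with a stated time of 48 h; a lower number here means a stronger inhibitor, a higher number a weaker inhibitor:
compound 1 `CS(=O)(=O)Nc1ccc(-n2cc(COc3ccccc3Cl)nn2)cc1Oc1ccccc1`: 25300 nM
compound 2 `CS(=O)(=O)Nc1ccc(-n2cc(-c3ccccc3)nn2)cc1Oc1ccccc1`: 13600 nM
compound 3 `Cc1ccc(OCc2cn(-c3ccc(NS(C)(=O)=O)c(Oc4ccccc4)c3)nn2)cc1`: 13000 nM

Compound 1 stands level with the other two, and between those two lies a 1.0-fold lower number from compound 2 to compound 3 (0.02 log units; within the scatter).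

Compound 4 `Cc1ccc(-c2cn(-c3ccc(NS(C)(=O)=O)c(Oc4ccccc4)c3)nn2)cc1` has not yet been measured. It carries 4-methylphenyl in place of (2-chlorophenoxy)methyl on an aromatic carbon.

Two measured steps each cover part of this exchange. The first puts phenyl in place of (2-chlorophenoxy)methyl on an aromatic carbon, giving a 1.9-fold lower number from compound 1 to compound 2 (0.27 log units; within the scatter). The second puts 4-methylphenyl in place of 2-chlorophenyl on an oxygen on a saturated carbon, giving a 1.9-fold lower number from compound 1 to compound 3 (0.29 log units; within the scatter). Neither step leaves the scatter, so no step beyond it is expected in this assay, though any drift would be expected toward a lower number.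

The expected outcome is a 1.9-fold lower number from compound 1 to compound 4 (0.29 log units; within the scatter).

For compound 4 the estimated value is 13000 nM, with an expected range from 6500 nM to 26000 nM.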

Compound 4, half-maximal inhibitory concentration: 18300 nM
Compound 4: the middle estimate sits 1.4-fold (0.15 log units) below what was measured; the range from low to high includes it.
By their numbers in this assay, from the lowest: compounds 3, 2, 4 and 1 (each within the scatter of the next).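

In this assay, compound 4 shows that 4-methylphenyl on this aromatic carbon of the five-membered aromatic ring with 3 nitrogen reads alike with each group tried there before: it replaces (2-chlorophenoxy)methyl (a 1.4-fold lower number from compound 1 to compound 4 (0.14 log units; within the scatter)) and (4-methylphenoxy)methyl (a 1.4-fold higher number from compound 3 to compound 4 (0.15 log units; within the scatter)) without leaving the scatter. The added methyl, in place of hydrogen on an aromatic carbon, also stays within the scatter (a 1.3-fold higher number from compound 2 to compound 4 (0.13 log units; within the scatter)), and so all four compounds remain level in this assay. No available measurement bears on what lies behind these small steps.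

The compounds shown leave open whether any group at this aromatic carbon can move the number beyond the scatter. As far as these compounds go, an amine or a carboxylic acid on the entering phenyl ring, or a longer chain in place of the methyl, remains untested here.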